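Compound 1 to compound 4: swapping the ester group

The source may hold more compounds than are shown below. What is called first, only, known or untested is meant among the compounds shown, and "the series" means these compounds.

In a functional assay on liver (Rattus norvegicus, strain Sprague-Dawley) for inhibition, with a stated time of 1 h (on this read-out higher numbers stand for weaker inhibition and lower numbers for stronger inhibition), compound 1 `COc1cc(C2Oc3cc([C@H]4Oc5cc(O)cc(O)c5C(=O)[C@@H]4O)ccc3OC2COC(=O)c2ccc([N+](=O)[O-])cc2)ccc1O` gives 12600 nM, compound 2 `COc1cc(C2Oc3cc([C@H]4Oc5cc(O)cc(O)c5C(=O)[C@@H]4O)ccc3OC2COC(=O)c2cccc(Cl)c2)ccc1O` gives 14200 nM and compound 3 `COc1cc(C2Oc3cc([C@H]4Oc5cc(O)cc(O)c5C(=O)[C@@H]4O)ccc3OC2COC(=O)/C=C/c2ccc(Cl)cc2)ccc1O` gives 12000 nM. Compound 1 therefore stands within the scatter of both others, and the three form a flat set. Compound 4 `COc1cc(C2Oc3cc([C@H]4Oc5cc(O)cc(O)c5C(=O)[C@@H]4O)ccc3OC2COC(=O)/C=C/c2ccc(Br)cc2)ccc1O` awaits measurement. Its change from compound 1 is 2-(4-bromophenyl)ethenyl in place of 4-nitrophenyl on a carbonyl carbon. The most relevant step is a 1.1-fold lower number from compound 1 to compound 3 (0.02 log units; within the scatter), which brings in 2-(4-chlorophenyl)ethenyl. Two further steps are a 1.1-fold higher number from compound 1 to compound 2 (0.05 log units; within the scatter) and a 1.2-fold lower number from compound 2 to compound 3 (0.07 log units; within the scatter). None of the three leaves the scatter, so no step beyond it is expected in this assay. The expected step is a 1.1-fold lower number from compound 1 to compound 4 (0.02 log units; within the scatter). Compound 4 is estimated at 12000 nM, with an expected range of 6500 nM to 22000 nM.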

Compound 4, half-maximal inhibitory concentration: 16300 nM
Beside the measured number, compound 4's estimate is 1.4-fold (0.13 log units) below it, and the stated range covers the measured number.
By their numbers in this assay, from the lowest: compounds 3, 1, 2 and 4 (each within the scatter of the next).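

In this assay, the halogen exchange gives a 1.4-fold higher number from compound 3 to compound 4 (0.13 log units; within the scatter) with bromo in place of chloro on an aromatic carbon, so this change does not separate the pair. The larger exchanges on the carbonyl carbon give a 1.3-fold higher number from compound 1 to compound 4 (0.11 log units; within the scatter) and a 1.1-fold higher number from compound 2 to compound 4 (0.06 log units; within the scatter) and also stay within the scatter, so the four ester groups remain one flat set at this position. No available evidence bears on this flat result. Still open, going by these compounds, is whether an amine or a carboxylic acid on the aromatic ring, or a longer chain in place of the ethenyl, would leave this flat set.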